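The compounds below may be only part of what the source reports. "The series", "measured", "known", "first", "only" and "open" are said of these compounds alone.

Measured so far in a functional assay on SK-BR-3 cells (Homo sapiens) for antiproliferative activity, read by MTT assay, with a stated time of 72 h; a lower number here means a stronger inhibitor, a higher number a weaker inhibitor:
Compound 1 `C/C=C1/[C@H](O[C@@H]2O[C@H](CO)[C@@H](O)[C@H](O)[C@H]2O)OC=C(C(=O)OC)[C@H]1CC(=O)OCCc1ccc2c(c1)OCCO2` gives > 20000 nM, which is a limit of the assay and not a number.
Compound 2 `C/C=C1/[C@H](O[C@@H]2O[C@H](CO)[C@@H](O)[C@H](O)[C@H]2O)OC=C(C(=O)OC)[C@H]1CC(=O)OCCC1CCCCC1` gives 2000 nM.
Compound 3 `C/C=C1/[C@H](O[C@@H]2O[C@H](CO)[C@@H](O)[C@H](O)[C@H]2O)OC=C(C(=O)OC)[C@H]1CC(=O)OCCc1ccc(OC)cc1` gives > 20000 nM, again a limit of the assay.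

Compound 3 thus stands at the limit of > 20000 nM in this assay, at which 2 of the 3 values shown sit, where compound 1 also sits, and only compound 2 has a read number. For the measured compounds named here, the one readable step, an at least 10-fold higher number from compound 2 to compound 3 (1.00 log units; beyond the scatter), shows that the cyclohexyl compound sits well clear of the limit while the 4-methoxyphenyl compound does not; an at least 10-fold lower number from compound 1 to compound 2 (1.00 log units; beyond the scatter) points the same way for the 2,3-dihydro-1,4-benzodioxin-6-yl compound. a step that the two limits leave unreadable from compound 1 to compound 3 gives no size, both ends being limits.

Compound 4 `C=C(C)CCOC(=O)C[C@@H]1C(C(=O)OC)=CO[C@@H](O[C@@H]2O[C@H](CO)[C@@H](O)[C@H](O)[C@H]2O)/C1=C/C` is compound 3 with 1-methylethenyl in place of 4-methoxyphenyl on a saturated chain carbon, two bonds along the chain from an oxygen next to a carbonyl group. The entering group is, like cyclohexyl in compound 2, without a ring and without an aromatic system, whereas compound 1 and compound 3, both at the limit, carry aromatic groups at this place. The measured steps therefore speak for a move off the limit toward a lower number, but with compound 3 itself at a limit the size of that move cannot be tied down. For compound 4 the expected step in this assay is an at least 3.3-fold lower number from compound 3 to compound 4 (0.52 log units; beyond the scatter). Compound 4 is accordingly estimated at 6000 nM, between 1500 nM and 20000 nM, with a real chance that only a limit is returned.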

Compound 4, half-maximal inhibitory concentration: > 15000 nM
Compound 4: no number, only a limit; the forecaster's own chance of this, stated with the estimate: 35%; middle value at least 2.5-fold (0.39 log units) from the limit.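

In this assay, for the compounds shown here, compound 4, whose 1-methylethenyl group has no ring, returns only a limit and not a number, so taking away the aromatic ring at this place does not by itself give a read value: the limit of > 15000 nM in this assay, at which 1 of the 4 values shown sits. Set against cyclohexyl, the same group gives an at least 7.5-fold higher number from compound 2 to compound 4 (0.87 log units; beyond the scatter), which leaves compound 2 as the only one of the four compounds with a read number and shows that the other non-aromatic group at this place does not share its result. The steps to compound 4 from compound 1 and from compound 3 cannot be read, both ends being limits, so 1-methylethenyl cannot be ranked against 4-methoxyphenyl or 2,3-dihydro-1,4-benzodioxin-6-yl.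

As far as these compounds go, it remains open whether the read number of compound 2 belongs to the cyclohexyl ring in particular or would also be reached with a cyclopentyl ring, an open hexyl chain or a piperidine ring, an amine, on the same saturated chain carbon. Also open, from the compounds shown here alone, is where compound 1, compound 3 and compound 4 would fall in this assay if read beyond their limits.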